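Compound 1 and its 1-ethylpyrrolidin-2-yl counterpart, compound 4

A few compounds are considered here, and "the series" means these few. Any claim that something is new, unique, unknown or untested is made for them only; others in the source may bear on it.

Measured in a functional assay on the whole organism with Rattus norvegicus as the target; a lower number here means that less compound is needed, a higher number that more compound is needed for the effect:
- compound 1 `CCNCCNC(=O)c1cc(Cl)c(N)cc1OC`: > 30 mg/kg (a limit)
- compound 2 `CCN(CCNC(=O)c1cc(Cl)c(N)cc1OC)Cc1cccc(OC)c1`: 1 mg/kg
- compound 3 `CCN(CCNC(=O)c1cc(Cl)c(N)cc1OC)Cc1ccc(Cl)cc1Cl`: 10 mg/kg

Compound 1 has no exact number in this assay, and its > 30 mg/kg is a limit of the assay.

Compound 4 `CCN1CCCC1CNC(=O)c1cc(Cl)c(N)cc1OC` keeps the core of compound 1 but changes the side chain: 1-ethylpyrrolidin-2-yl in place of (ethylamino)methyl on a saturated chain carbon bound to an amide-type nitrogen.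

Among the measured compounds shown here, no measured step makes this change. The nearest evidence is the two steps that replace the hydrogen on the amine nitrogen of compound 1 with a substituted benzyl group, an at least 30-fold lower number from compound 1 to compound 2 (1.47 log units; beyond the scatter) and an at least 3.0-fold lower number from compound 1 to compound 3 (0.47 log units; beyond the scatter). The size of that gain depends on the group, as a 10-fold higher number from compound 2 to compound 3 (1.00 log units; beyond the scatter) shows. Compound 4 also lacks that hydrogen, but it carries no benzyl group, so these steps give only weak guidance. A modest move towards a lower number is expected, smaller than an at least 30-fold lower number from compound 1 to compound 2 (1.47 log units; beyond the scatter).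

The expected change is an at least 2.0-fold lower number from compound 1 to compound 4 (0.30 log units; that floor lies within the scatter). Compound 4 is estimated at 15 mg/kg, within an expected range of 4 mg/kg to 40 mg/kg.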

Compound 4, dose for half-maximal effect: > 30 mg/kg
Compound 4: only a limit was reported (the forecaster's own chance of this, stated with the estimate: 30%); at least 2.0-fold (0.30 log units) between middle value and limit.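

Among the compounds shown here, compound 4, like compound 1, is reported only as a limit, so no step between the two can be read, because both values rest on the same limit: the limit of > 30 mg/kg in this assay, at which 2 of the 4 values shown sit.
The compounds shown leave open whether 1-ethylpyrrolidin-2-yl in place of (ethylamino)methyl changes the dose needed at all, and by how much.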